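Swapping the chlorine position on a pyridine-linked phenol series

A few compounds are considered here, and "the series" means these few. Any claim that something is new, unique, unknown or untested is made for them only; others in the source may bear on it.

Compound 1 `Oc1ccc(-c2cc(-c3ccco3)nc(-c3ccccc3Cl)c2)cc1`: 5460 nM
Compound 2 `Oc1cccc(-c2cc(-c3ccc(Cl)cc3)nc(-c3ccsc3)c2)c1`: 8850 nM
Compound 3 `Oc1cccc(-c2cc(-c3ccc(Cl)cc3)nc(-c3ccco3)c2)c1`: 10200 nM

In a functional assay on HCT-15 cells (Homo sapiens) for cytotoxicity, read by CCK-8 assay and cell counting, with a stated time of 2 days (on this read-out lower numbers stand for stronger inhibition and higher numbers for weaker inhibition), compound 3 stands with the highest number of the three, though its distance to compound 2 and to compound 1 lies within the scatter. Compound 4 `Oc1cccc(-c2cc(-c3ccco3)nc(-c3ccccc3Cl)c2)c1` differs from compound 3 by 2-chlorophenyl in place of 4-chlorophenyl on an aromatic carbon, on the aromatic carbon next to the ring nitrogen. Among the measured compounds shown here, no measured step exchanges one chlorophenyl for another; the only step available, a 1.2-fold higher number from compound 2 to compound 3 (0.06 log units; within the scatter), concerns a different position and lies within the scatter. Compound 1, which also carries the 2-chlorophenyl group, gives 5460 nM. Compound 4 is therefore expected to give 7000 nM, between 3000 nM and 16000 nM, a change of a 1.5-fold lower number from compound 3 to compound 4 (0.16 log units; within the scatter) from compound 3.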

Compound 4, half-maximal inhibitory concentration: 2230 nM
For compound 4 the middle estimate is 3.1-fold (0.50 log units) above the measured one; the measured number lies below the stated range.
By their numbers in this assay, from the lowest: compound 4; then compounds 1, 2 and 3 (each within the scatter of the next).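

Replacing 4-chlorophenyl with 2-chlorophenyl on the carbon next to the ring nitrogen gives a 4.6-fold lower number from compound 3 to compound 4 (0.66 log units; beyond the scatter) and is the first change shown here to clear the scatter. The hydroxyl placement also counts in this series, since 3-hydroxyphenyl in place of 4-hydroxyphenyl gives a 2.4-fold lower number from compound 1 to compound 4 (0.39 log units; beyond the scatter) with the 2-chlorophenyl group kept. Nothing available explains either step. Still open, as far as these compounds go, is whether a 2-aminophenyl group could replace 2-chlorophenyl and keep this lower number. Also open, from the compounds shown here alone, is whether 2-chlorophenyl would have the same effect with thiophen-3-yl in place of furan-2-yl.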